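The compounds below may be only part of what the source reports. "The series", "measured", "known", "first", "only" and "open" are said of these compounds alone.

In a functional assay on HCT-116 cells (Homo sapiens) for antiproliferative activity, read by MTT assay, with a stated time of 72 h (on this read-out higher numbers stand for weaker inhibition and lower numbers for stronger inhibition), compound 1 `NC1=NC2(CCSCC2)N(OCCCOc2cccc(Cl)c2)C(N)=N1` gives 1 nM, compound 2 `NC1=NC2(CCSCC2)N(OCCCOc2cc(Cl)c(Cl)cc2Cl)C(N)=N1` gives 1 nM, and compound 3 `NC1=NC2(CCSCC2)N(OCCCOc2ccccc2Cl)C(N)=N1` gives 1 nM, which places compound 3 level with the other two. Compound 4 `NC1=NC2(CCSCC2)N(OCCCOc2cccc(Br)c2)C(N)=N1` has not yet been measured. It carries 3-bromophenyl in place of 2-chlorophenyl on an oxygen on a saturated carbon. Three measured swaps of the group at that place bear on this change: no change at the digits printed from compound 1 to compound 3 (within the scatter), no change at the digits printed from compound 1 to compound 2 (within the scatter) and no change at the digits printed from compound 2 to compound 3 (within the scatter). All three stay within the scatter, although none of them tests a bromine-bearing group. In this assay, the expected change is therefore none beyond the scatter, with an estimated no change at the digits printed from compound 3 to compound 4 (within the scatter). Compound 4 is expected to give 1 nM, with an estimated range of 0.4 nM to 3 nM.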

Compound 4, half-maximal inhibitory concentration: 1 nM
The estimate for compound 4 equals the measured number at the digits printed; measured number inside the range.
By their numbers in this assay, from the lowest: compounds 1, 2, 3 and 4 (each within the scatter of the next).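

In this assay, among these compounds, a bromine now stands on the phenyl ring for the first time, and bromo in place of chloro on an aromatic carbon gives (no change at the digits printed from compound 1 to compound 4 (within the scatter)). The two other swaps at this position read the same (no change at the digits printed from compound 3 to compound 4 (within the scatter)) and (no change at the digits printed from compound 2 to compound 4 (within the scatter)), so all four halogen-bearing phenyl groups sit within the scatter of one another. Nothing measured here offers an explanation for this. Still open, as far as these compounds go, is how this position responds to a phenyl ring carrying an amine or a carboxylic acid, or to a longer chain on the oxygen.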